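A few compounds are considered here, and "the series" means these few. Any claim that something is new, unique, unknown or untested is made for them only; others in the source may bear on it.

Compound 1 `O=C(O)c1cc(-c2ccc(-c3ccc(Cl)cc3Cl)cc2)n(-c2ccccn2)n1` carries a pyridin-2-yl group on the shared core. In an assay on isolated protein for inhibition of methionine--tRNA ligase, cytoplasmic (Homo sapiens) (on this read-out lower numbers stand for stronger inhibition and higher numbers for weaker inhibition), compound 1 yields only a limit, > 100000 nM, not a measured number; this is the limit of > 100000 nM in this assay, at which 1 of the 2 values shown sits. Compound 2 `O=C(O)c1cc(-c2ccc(-c3ccc(Cl)cc3Cl)cc2)nn1Cc1ccccn1`, a near relative, gives 22300 nM in this assay. Compound 3 `O=C(O)c1cc(-c2ccc(-c3ccc(Cl)cc3Cl)cc2)n(Cc2ccncc2)n1` differs from compound 1 by (pyridin-4-yl)methyl in place of pyridin-2-yl on an aromatic nitrogen. Compound 2 gives 22300 nM, which suggests compound 3 may reach a measurable number. The step of an at least 2.8-fold lower number from compound 1 to compound 3 (0.45 log units; beyond the scatter) is therefore expected to lean toward stronger inhibition. Compound 3 is estimated at 35000 nM, within 12000 nM to 100000 nM.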

Compound 3, half-maximal inhibitory concentration: 26200 nM
Beside the measured number, compound 3's estimate is 1.3-fold (0.13 log units) above it, and the stated range covers the measured number.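

With (pyridin-4-yl)methyl on this aromatic nitrogen, inhibition becomes measurable in this assay, a step of an at least 3.8-fold lower number from compound 1 to compound 3 (0.58 log units; beyond the scatter). This position, next to the ring atom that bears a large group, can therefore carry a group that gives a real number. The true size of the step stays unknown because compound 1 gives only a limit: the limit of > 100000 nM in this assay, at which 1 of the 3 values shown sits.

The change adds a methylene link and also moves the ring nitrogen, and these two effects cannot be separated here. On these data alone, how a plain benzyl group or a longer chain would behave at this position also remains open.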